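Removing the chloro group from compound 3

A few compounds are considered here, and "the series" means these few. Any claim that something is new, unique, unknown or untested is made for them only; others in the source may bear on it.

Compound 3 `O=[N+]([O-])c1ccc(Cl)cc1CNc1cc(C(F)(F)F)cc2[nH]ncc12` gives 35% in an assay for inhibition of Indoleamine 2,3-dioxygenase 1 (Homo sapiens), with stated times of 10 min and 60 min, tested at 10 uM; a lower number here means a weaker effect, a higher number a stronger effect of the compound at the concentration tested. That is the highest of the three numbers on hand, though the gap to compound 1 `O=[N+]([O-])c1ccccc1CNc1cccc2[nH]ncc12`, which gives 25%, lies within the usual scatter; only compound 2 `COC(=O)c1cc(NCc2ccccc2[N+](=O)[O-])c2cn[nH]c2c1`, with 11%, stands clearly apart. Within the data shown here, the one single-point step measured so far runs a number 14 percentage points lower from compound 1 to compound 2 (beyond the scatter), a methoxycarbonyl entering in place of hydrogen on an aromatic carbon, and it does not touch the change now at hand. Compound 4 `O=[N+]([O-])c1ccccc1CNc1cc(C(F)(F)F)cc2[nH]ncc12` differs from compound 3 in one place: hydrogen in place of chloro on an aromatic carbon. Among the measured compounds shown here, no measured pair isolates this change; compounds 1 and 3 differ in two places at once, and their values sit within the scatter of each other. With nothing pointing to a shift beyond the scatter, the step from compound 3 to compound 4 is expected to be small, a number 7 percentage points lower from compound 3 to compound 4 (within the scatter), in either direction or none. Compound 4 is therefore estimated at 28%, within 14% to 42%.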

Compound 4, a percentage reported as inhibition, at one concentration (the size of the read-out at that concentration, not a potency): 35%
For compound 4 the middle estimate is 7 percentage points below the measured one; low and high end bracket the measured number.
By their numbers in this assay, from the lowest: compound 2; then compounds 1, 3 and 4 (each within the scatter of the next).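

In this assay, among these compounds, the chloro group on the carbon para to a nitro group can give way to hydrogen with the read-out unmoved: no change at the digits printed from compound 3 to compound 4 (within the scatter), the first direct look at this change. On the other side of the molecule, trifluoromethyl against hydrogen gives a number 10 percentage points higher from compound 1 to compound 4 (within the scatter), whereas trifluoromethyl against methoxycarbonyl gives a number 24 percentage points higher from compound 2 to compound 4 (beyond the scatter), so only the second of these two substitutions stands clear of the scatter. Nothing measured here offers a reason for any of these steps.

As far as these compounds go, whether an amine or a methoxy group on that same carbon would move the number beyond the scatter remains open. The nitro group stands in all the compounds shown, so what replacing it with a nitrile or a carboxylic acid would do is also unknown.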